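The compounds below may be only part of what the source reports. "The series", "measured", "known", "first", "only" and "open" are said of these compounds alone.

In an in vitro functional assay on HEK293S cells for agonist activity at Glucose-dependent insulinotropic receptor (Homo sapiens), read by HTRF and cAMP accumulation, with a stated time of 45 min (a lower number here means that less compound is needed, a higher number that more compound is needed for the effect), compound 1 `CC(C)(C)OC(=O)N1CCN(c2cnc(OCc3ccc(S(C)(=O)=O)cc3)nc2)CC1` gives 1080 nM and compound 2 `CC(C)(C)OC(=O)N1CCN(c2ccc(OCc3ccc(S(C)(=O)=O)cc3)cn2)CC1` gives 186 nM. Compound 3 `C[C@@H]1CN(C(=O)OC(C)(C)C)CCN1c1ncc(OCC2CCN(S(C)(=O)=O)CC2)cn1` gives 29 nM in this assay, the lowest of the three numbers; compound 2 sits nearest and compound 1 furthest, both beyond the scatter. Compound 4 `C[C@@H]1CN(C(=O)OC(C)(C)C)CCN1c1ncc(OCc2ccc(C#N)cc2)cn1` differs from compound 3 by 4-cyanophenyl in place of 1-(methylsulfonyl)piperidin-4-yl on a saturated chain carbon bound to an oxygen on an aromatic ring. Within the data shown here, no measured pair shows this exchange, so the step from compound 3 to compound 4 in this assay can only be expected: a moderate rise in the number, beyond the scatter, is estimated, as a 3.4-fold higher number from compound 3 to compound 4 (0.54 log units; beyond the scatter). Compound 4 is accordingly expected to give about 100 nM in this assay, within a range from 25 nM to 400 nM.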

Compound 4, half-maximal effective concentration: 39 nM
Beside the measured number, compound 4's estimate is 2.6-fold (0.41 log units) above it, within the range that was stated.
By their numbers in this assay, from the lowest: compounds 3 and 4 (each within the scatter of the next); then compound 2; then compound 1.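

In this assay, 4-cyanophenyl in place of 1-(methylsulfonyl)piperidin-4-yl on a saturated chain carbon bound to an oxygen on an aromatic ring gives a 1.3-fold higher number from compound 3 to compound 4 (0.13 log units; within the scatter) and so leaves the number unchanged within the scatter. At this place, therefore, a six-membered aromatic ring of carbon only serves as well as a six-membered non-aromatic ring with a sulfonyl group on its nitrogen. No evidence at hand bears on why the two groups read alike. As far as these compounds go, whether an amine or a carboxylic acid on the same ring would read alike remains open, as does whether this exchange holds on the core of compound 2.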